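The compounds below may be only part of what the source reports. "The series", "measured", "known", "first", "only" and "open" are said of these compounds alone.

Compound 1 `O=C(Nc1ccc(-c2cscn2)cc1)C1CCCN(Cc2ccc(F)c(F)c2)C1`: 880 nM
Compound 2 `O=C(Nc1ccc(-c2cscn2)cc1)C1CCCN(Cc2cccc(F)c2)C1`: 2450 nM

Within the data shown here, in a functional assay on A-375 cells (Homo sapiens) for antiproliferative activity (on this read-out higher numbers stand for weaker inhibition and lower numbers for stronger inhibition), compound 1 gives 880 nM, the lower of the two numbers measured so far. Compound 3 `O=C(Nc1ccc(-c2ccccn2)cc1)C1CCCN(Cc2ccc(F)c(F)c2)C1` keeps the rest of compound 1 and changes one group: pyridin-2-yl in place of 1,3-thiazol-4-yl on an aromatic carbon. Put simply, it has pyridin-2-yl in place of 1,3-thiazol-4-yl on an aromatic carbon. Among the measured compounds shown here, only one measured step exists, a 2.8-fold higher number from compound 1 to compound 2 (0.44 log units; beyond the scatter). That step swaps hydrogen for fluoro, so it says nothing direct about this ring exchange. It only shows that a single edit in this series can move the number modestly. For the measured compounds named here, no measured compound tests the new group, so the direction remains open, and a modest step either way is expected in this assay. The estimated step is a 1.1-fold higher number from compound 1 to compound 3 (0.06 log units; within the scatter). For compound 3, the expected value is 1000 nM, with an estimated range of 320 nM to 3200 nM.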

Compound 3, half-maximal inhibitory concentration: 9000 nM
Estimate against measurement, compound 3: 9.0-fold (0.95 log units) below; the whole stated range lies below it.
By their numbers in this assay, from the lowest: compound 1; then compound 2; then compound 3.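

In this assay, the group on the aromatic carbon para to a large group turns out to matter a great deal: pyridin-2-yl in place of 1,3-thiazol-4-yl gives a large step (a 10-fold higher number from compound 1 to compound 3 (1.01 log units; beyond the scatter)). This step is clearly bigger than the only earlier one, the loss of a fluoro (a 2.8-fold higher number from compound 1 to compound 2 (0.44 log units; beyond the scatter)), so the exchange of one aromatic ring for another weakens inhibition more than that edit on the far side of the molecule does. Nothing available explains why these two rings differ so much.

The compounds shown leave open whether a plain phenyl ring or a pyridin-3-yl ring at this place would behave like 1,3-thiazol-4-yl or like pyridin-2-yl. They also leave open whether removing the same fluoro from compound 3 would change its number as it did for compound 1.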